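The source may report more compounds than this note shows. Statements on the series, on what has been measured and on what is new or still open speak of the compounds shown alone.

In a functional assay on HCT-8 cells (Homo sapiens) for antiproliferative activity, read by MTT assay, with a stated time of 48 h (on this read-out higher numbers stand for weaker inhibition and lower numbers for stronger inhibition), the measured compounds are as follows:
- compound 1 (`COc1ccc(C(=O)c2ccc(OC)c3c2OC(C)(C)C=C3)c(NC(=O)CBr)c1`) gives 3250 nM
- compound 2 (`CNCC(=O)Nc1cc(OC)ccc1C(=O)c1ccc(OC)c2c1OC(C)(C)C=C2`) gives 740 nM
- compound 3 (`CCNCC(=O)Nc1cc(OC)ccc1C(=O)c1ccc(OC)c2c1OC(C)(C)C=C2`) gives 3690 nM

Within the data shown here, compound 3 stands level with compound 1 (a 1.1-fold higher number from compound 1 to compound 3 (0.06 log units; within the scatter)), while compound 2 holds the only clearly lower number (a 5.0-fold higher number from compound 2 to compound 3 (0.70 log units; beyond the scatter)).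

Compound 4 (`COc1ccc(C(=O)c2ccc(OC)c3c2OC(C)(C)C=C3)c(NC(=O)CN(C)C)c1`) has dimethylamino in place of ethylamino on a saturated chain carbon bound to a carbonyl carbon. Among the measured compounds shown here, no measured step makes this exact exchange, so the evidence is indirect. The amine group clearly matters here, as the modest gap between compound 2 and compound 3 shows (a 5.0-fold higher number from compound 2 to compound 3 (0.70 log units; beyond the scatter)). The exchange of bromo for methylamino from compound 1 to compound 2 is of similar size (a 4.4-fold lower number from compound 1 to compound 2 (0.64 log units; beyond the scatter)), whereas the exchange of bromo for ethylamino stays within the scatter (a 1.1-fold higher number from compound 1 to compound 3 (0.06 log units; within the scatter)). A modest move towards a lower number is therefore expected in this assay, although a result level with compound 3 would not be surprising. The expected step is a 2.2-fold lower number from compound 3 to compound 4 (0.34 log units; beyond the scatter) in this estimate. Compound 4 is estimated at 1700 nM, with an expected range from 600 nM to 4500 nM.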

Compound 4, half-maximal inhibitory concentration: 1590 nM
For compound 4 the middle estimate is 1.1-fold (0.03 log units) above the measured one, and the stated range covers the measured number.
By their numbers in this assay, from the lowest: compound 2; then compound 4; then compounds 1 and 3 (each within the scatter of the next).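

In this assay the two groups have the same atoms joined differently, and dimethylamino in place of ethylamino on this saturated chain carbon still gives a 2.3-fold lower number from compound 3 to compound 4 (0.37 log units; beyond the scatter) in a modest step, so the atom count of the amine does not settle the result here. Methyl in place of hydrogen on the amine nitrogen gives a 2.1-fold higher number from compound 2 to compound 4 (0.33 log units; beyond the scatter) and leaves compound 2 with the lower number, while dimethylamino in place of bromo gives a 2.0-fold lower number from compound 1 to compound 4 (0.31 log units; beyond the scatter) in a further modest step, so compounds 2 and 4 both move beyond the scatter from bromo and compound 3 goes against that pattern. No measurement shown here accounts for these differences. The compounds shown leave open how diethylamino would read at this place, and how a longer chain between the carbonyl and the amine would read.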